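Extending a Piperidine Methyl to Benzyl: Expected Potency

The compounds below may be only part of what the source reports. "The series", "measured", "known", "first", "only" and "open" are said of these compounds alone.

Measured compounds:
Compound 1, `CCCN(CCC)c1cc(C(F)(F)F)ccc1CNC(=O)C(C)c1ccc(NS(C)(=O)=O)c(F)c1`: 0.3 nM
Compound 2, `CC1CCN(c2cc(C(F)(F)F)ccc2CNC(=O)C(C)c2ccc(NS(C)(=O)=O)c(F)c2)CC1`: 0.9 nM

Both compounds were tested in an assay on CHO cells for antagonist activity at transient receptor potential cation channel subfamily V member 1 (Homo sapiens), read by FLIPR; on this read-out lower numbers stand for stronger inhibition and higher numbers for weaker inhibition. Compound 1 gives 0.3 nM, and compound 2 gives 0.9 nM. Among the compounds with values here, compound 2 therefore carries the higher of the two numbers, and its only neighbour is compound 1, with a 3.0-fold higher number from compound 1 to compound 2 (0.48 log units; beyond the scatter), a step that exchanges one amine substituent for another on the aromatic ring of the shared core.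

Compound 3, `CC(C(=O)NCc1ccc(C(F)(F)F)cc1N1CCC(Cc2ccccc2)CC1)c1ccc(NS(C)(=O)=O)c(F)c1`, keeps the piperidine of compound 2 and differs only in this way: phenyl in place of hydrogen on a saturated chain carbon bound to a saturated ring carbon. Within the data shown here, no measured step tests such an addition; the single step on hand, a 3.0-fold higher number from compound 1 to compound 2 (0.48 log units; beyond the scatter), concerns a different place and gives no guide to a larger group on the saturated ring. The step from compound 2 to compound 3 is therefore expected to be a 2.2-fold higher number from compound 2 to compound 3 (0.35 log units; beyond the scatter), a guess held loosely. Compound 3 is estimated at 2 nM, within a range of 0.4 nM to 10 nM.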

Compound 3, inhibition constant: 1.4 nM
Compound 3: the middle estimate sits 1.4-fold (0.15 log units) above what was measured; measured number inside the range.
By their numbers in this assay, from the lowest: compound 1; then compounds 2 and 3 (each within the scatter of the next).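

In this assay, placing phenyl in place of hydrogen on a saturated chain carbon bound to a saturated ring carbon, which turns methyl into benzyl, gives a 1.6-fold higher number from compound 2 to compound 3 (0.19 log units; within the scatter). This position on the piperidine therefore accepts an added six-membered aromatic ring without a change that this read-out can separate from the scatter, something the earlier step, made at a different place, could not show. Nothing on hand explains this result.

On these data alone, how far this tolerance extends remains open: a longer chain such as phenylethyl in place of benzyl might or might not read the same. As far as these compounds go, it is equally open whether an amine or a carboxylic acid at the end of the methyl chain would fit this pattern.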